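Moving a Single Fluoro on the Amide Aryl Ring

A few compounds are considered here, and "the series" means these few. Any claim that something is new, unique, unknown or untested is made for them only; others in the source may bear on it.

Measured compounds:
- compound 1, `Cc1c(C(=O)Nc2cccc(F)c2)cnn1-c1ccc(F)cc1`: 3000 nM
- compound 2, `COc1cccc(NC(=O)c2cnn(-c3ccc(F)cc3)c2C)c1`: 3700 nM
- compound 3, `Cc1c(C(=O)Nc2cccc(C(F)(F)F)c2)cnn1-c1ccc(F)cc1`: 1700 nM

All three share one core and differ only in the aryl group on the amide nitrogen. In a functional assay with Homo sapiens as the target (a higher number here means a weaker inhibitor, a lower number a stronger inhibitor), compound 2 gives the highest of the three numbers. Its nearest neighbour is compound 1, with a 1.2-fold higher number from compound 1 to compound 2 (0.09 log units; within the scatter) lying within the scatter, so the two cannot be ranked. Compound 3 stands furthest away, with a 2.2-fold lower number from compound 2 to compound 3 (0.34 log units; beyond the scatter), a modest step beyond the scatter. Between compound 1 and compound 3 the step is a 1.8-fold lower number from compound 1 to compound 3 (0.25 log units; within the scatter), again within the scatter.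

Compound 4, `Cc1c(C(=O)Nc2ccccc2F)cnn1-c1ccc(F)cc1`, has not yet been measured. It differs from compound 2 in one place: 2-fluorophenyl in place of 3-methoxyphenyl on an amide-type nitrogen. For the measured compounds named here, the step that bears most on it is the one from compound 1 to compound 2, where methoxy in place of fluoro on an aromatic carbon changed nothing beyond the scatter. In compound 4 the fluoro returns, now as a 2-fluorophenyl, an arrangement not covered by any measured pair, so the expectation rests on that single step and carries wide uncertainty.

Compound 4 is therefore expected to land close to compound 2, with a 1.2-fold lower number from compound 2 to compound 4 (0.09 log units; within the scatter) as the estimated step. The estimate for compound 4 in this assay is 3000 nM, with a range from 1200 nM to 7500 nM.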

Compound 4, half-maximal inhibitory concentration: 4000 nM
For compound 4 the middle estimate is 1.3-fold (0.12 log units) below the measured one; measured number inside the range.
By their numbers in this assay, from the lowest: compounds 3, 1, 2 and 4 (each within the scatter of the next, the first and the last beyond it).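

Swapping the 3-methoxyphenyl on the amide-type nitrogen for 2-fluorophenyl gives a 1.1-fold higher number from compound 2 to compound 4 (0.03 log units; within the scatter) in this assay and so cannot be told apart from no change at all. For the compounds shown here, the more telling comparison keeps the fluoro and changes only its place on the ring, going from 3-fluorophenyl to 2-fluorophenyl, which gives a 1.3-fold higher number from compound 1 to compound 4 (0.12 log units; within the scatter) and shows for the first time that this shift also leaves the number within the scatter. No supporting measurement is available that would account for this flat result.

The amide aryl rings shown carry a fluoro, a methoxy or a trifluoromethyl, so it remains open how this assay would respond to an amine or a carboxylic acid on that ring, or to an aryl ring with two fluoro groups. The methyl on the shared core also stays the same throughout, which leaves open what a longer chain such as ethyl would do there.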